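From dichloro to difluoro: an estimate for compound 3

This account rests on a few compounds, and the source may have more. Where it says the series, first, only, none or still open, it means among the compounds named here.

Compound 1 `COc1ccc(-c2cc(/C=C/C(=O)c3ccc(N)cc3)[nH]n2)cc1`, measured in a functional assay on Malme-3M cells (Homo sapiens) for inhibition, read by sulforhodamine B assay, with a stated time of 48 h; on this read-out lower numbers stand for stronger inhibition of growth and higher numbers for weaker inhibition of growth: compound 1 gives 6220 nM.
Compound 2 `COc1cc(-c2cc(/C=C/C(=O)c3ccc(Cl)c(Cl)c3)[nH]n2)cc(OC)c1OC`, measured in this assay: compound 2 gives > 100000 nM.

Going by the values given here, of the two measured values, only that of compound 1 is a number. For compound 2 the result is a limit of the assay, not a number: the limit of > 100000 nM in this assay, at which 1 of the 2 values shown sits. Compound 2 therefore stands at the weak end of what this assay can report, and nothing closer can be said about it.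

Compound 3 `COc1cc(-c2cc(/C=C/C(=O)c3ccc(F)c(F)c3)[nH]n2)cc(OC)c1OC` differs from compound 2 in one place: 3,4-difluorophenyl in place of 3,4-dichlorophenyl on a carbonyl carbon. Among the compounds with values here, no measured step between compounds covers a change of this kind, so the expectation rests on the position of compound 2 alone. The step from compound 2 to compound 3 is expected to be small, with no direction that could be told from the scatter, giving an at least 1.2-fold lower number from compound 2 to compound 3 (0.09 log units; that floor lies within the scatter). Compound 3 is therefore estimated to give 80000 nM in this assay, within a range from 20000 nM to 300000 nM, and it may well again return only a limit.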

Compound 3, concentration for total growth inhibition: 9400 nM
Beside the measured number, compound 3's estimate is 8.5-fold (0.93 log units) above it; the whole stated range lies above it.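

At this position, on a carbonyl carbon, the two halogenated rings are not interchangeable in this assay: 3,4-difluorophenyl in place of 3,4-dichlorophenyl gives an at least 10-fold lower number from compound 2 to compound 3 (1.02 log units; beyond the scatter). The earlier compounds shown here offered no step at all, and this first one shows that a swap leaving the heavy-atom count, the hydrogen-bond donors and acceptors and the net charge the same can still move the read-out beyond the scatter. The step is only a floor and its full size stays unknown, because compound 2 stands at a limit and not at a number: the limit of > 100000 nM in this assay, at which 1 of the 3 values shown sits.

The compounds shown leave open whether the gain follows the fluorine atoms themselves or simply the loss of chlorine, a question that a 3,4-dibromophenyl group, a single chlorine, a single fluorine or an unsubstituted phenyl at the same place would help to settle. As far as these compounds go, compound 1 differs from the other two in more than one place, so it also remains open what the aminophenyl group of compound 1 would give on the core shared by compound 2 and compound 3.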